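A few compounds are considered here, and "the series" means these few. Any claim that something is new, unique, unknown or untested is made for them only; others in the source may bear on it.

Working notes on the series in an assay on isolated protein for inhibition of Amine oxidase [flavin-containing] B (Homo sapiens), read by fluorescence and spectrophotometry; on this read-out higher numbers stand for weaker inhibition and lower numbers for stronger inhibition. The shared core carries a three-carbon amide arm terminating in a substituted anilide. Compound 1 `Cc1ccc(NC(=O)CCc2cn(Cc3ccc4oc(-c5ccccc5)cc(=O)c4c3)nn2)cc1` gives 15600 nM. Compound 2 `O=C(CCc1cn(Cc2ccc3oc(-c4ccccc4)cc(=O)c3c2)nn1)Nc1ccc(Cl)cc1` gives 15600 nM. Compound 3 `O=C(CCc1cn(Cc2ccc3oc(-c4ccc(Cl)cc4)cc(=O)c3c2)nn1)Nc1ccc(Cl)cc1` gives 32900 nM. Compound 2 stands level with compound 1 at the digits shown, the two together the lowest numbers of the three; compound 3 is furthest from it.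

Two steps are on record. The step of no change at the digits printed from compound 1 to compound 2 (within the scatter) shows that swapping the group at this position on the anilide ring changes nothing within the scatter. The step of a 2.1-fold higher number from compound 2 to compound 3 (0.32 log units; beyond the scatter) adds a chloro on the pendant phenyl of the core and moves the number modestly higher.

Compound 4 `O=C(CCc1cn(Cc2ccc3oc(-c4ccccc4)cc(=O)c3c2)nn1)Nc1ccc(F)cc1` differs from compound 2 by fluoro in place of chloro on an aromatic carbon. For the measured compounds named here, the only step bearing on this position, no change at the digits printed from compound 1 to compound 2 (within the scatter), is flat, and the change keeps one heavy atom in place of another; a step of no more than the scatter is therefore expected, in either direction. For compound 4 the estimate in this assay is 18000 nM, with a range from 9000 nM to 36000 nM. The expected step of a 1.2-fold higher number from compound 2 to compound 4 (0.06 log units; within the scatter) is essentially flat.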

Compound 4, half-maximal inhibitory concentration: 15600 nM
For compound 4 the middle estimate is 1.2-fold (0.06 log units) above the measured one, within the range that was stated.
By their numbers in this assay, from the lowest: compounds 1, 2 and 4 (each within the scatter of the next); then compound 3.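

In this assay the step of no change at the digits printed from compound 2 to compound 4 (within the scatter) and the step of no change at the digits printed from compound 1 to compound 4 (within the scatter) widen what was a single flat pair into a set of three: methyl, chloro and fluoro on this aromatic carbon, para to a large group, all lie within the scatter of one another. The read-out therefore gives no ranking among these three groups at this position, and the flat result now holds for the exchange of one halogen for another as well as for methyl to chloro. The data shown offer no explanation for this flatness.

As far as these compounds go, whether an amine, a carboxylic acid or a methoxy group at this position would move the number remains open. Also open, from the compounds shown here alone, is whether the fluoro anilide would respond to a chloro on the pendant phenyl of the core as the chloro anilide does.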